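Bromo to methyl on the aryl triazole

The source may hold more compounds than are shown below. What is called first, only, known or untested is meant among the compounds shown, and "the series" means these compounds.

Within the data shown here, compound 1 `O=C1O[C@H]([C@@H](O)Cn2cc(-c3ccc(Br)cc3)nn2)C(OCc2ccccc2)=C1OCc1ccccc1` holds the only number in a functional assay on HCT-116 cells (Homo sapiens) for antiproliferative activity, read by MTT assay, with a stated time of 72 h; a lower number here means a stronger inhibitor, a higher number a weaker inhibitor: compound 1 gives 9420 nM. Compound 2 `COc1ccc(-c2cn(C/C=C3\OC(=O)C(OCc4ccccc4)=C3OCc3ccccc3)nn2)cc1` sits at the limit of > 100000 nM in this assay, at which 1 of the 2 values shown sits. In this assay compound 2 gives > 100000 nM, which is a limit of the assay and not a number. Among the measured compounds shown here, no step between measured compounds can therefore be sized. Compound 3 `Cc1ccc(-c2cn(C[C@H](O)[C@H]3OC(=O)C(OCc4ccccc4)=C3OCc3ccccc3)nn2)cc1` differs from compound 1 by methyl in place of bromo on an aromatic carbon. Without a measured step of this kind, a change no larger than the scatter is expected in this assay, in either direction. For compound 3 the estimate is 12000 nM, between 4000 nM and 40000 nM. The expected step is a 1.3-fold higher number from compound 1 to compound 3 (0.11 log units; within the scatter).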

Compound 3, half-maximal inhibitory concentration: > 100000 nM
Compound 3 gave a limit, no number (the forecaster's own chance of this, stated with the estimate: 10%); middle value at least 8.3-fold (0.92 log units) from the limit.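

At the position para to a large group on the aromatic ring, methyl in place of bromo is not a neutral change in this assay: it gives an at least 10-fold higher number from compound 1 to compound 3 (1.02 log units; beyond the scatter). The value of compound 3 is a limit of the assay and not a number, so the full size of the step cannot be read. On this core, the measurable activity of compound 1 does not survive this single change, and the same limit recurs among the compounds shown: the limit of > 100000 nM in this assay, at which 2 of the 3 values shown sit.

On these data alone, whether a chlorine atom, a fluorine atom or a nitrile at this place would keep a measurable value remains open. So does whether bromo is specifically required there.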